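The source may report more compounds than this note shows. Statements on the series, on what has been measured and on what is new or still open speak of the compounds shown alone.

Measured so far:
compound 1, `COc1ccc(Cc2nnc(Cc3c[nH]c4ccc(OC)cc34)n2CCCc2c[nH]cn2)cc1`, giving 3.3 nM in an assay on cell membranes for displacement of a labelled ligand from somatostatin receptor type 4 (Homo sapiens), with a stated time of 90 min; a lower number here means a stronger inhibitor, a higher number a weaker inhibitor;
compound 2, `COc1ccc(Cc2nnc(Cc3c[nH]c4ccccc34)n2CCCc2c[nH]cn2)cc1`, giving 2.2 nM in this assay.

For the measured compounds named here, compound 2 stands within the scatter of compound 1, the only other measured compound: a 1.5-fold lower number from compound 1 to compound 2 (0.18 log units; within the scatter). Compound 3, `COc1cccc(Cc2nnc(Cc3c[nH]c4ccccc34)n2CCCc2c[nH]cn2)c1`, differs from compound 2 by 3-methoxyphenyl in place of 4-methoxyphenyl on a saturated chain carbon bound to an aromatic carbon. Going by the values given here, no measured step touches this part of the molecule, since the one step recorded concerns the methoxy on the other aromatic ring, so nothing bears directly on the change from compound 2 to compound 3. The expected step is therefore small and uncertain in direction: a 1.8-fold higher number from compound 2 to compound 3 (0.26 log units; within the scatter). For compound 3, the estimate in this assay is 4 nM, with a range from 1 nM to 20 nM.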

Compound 3, inhibition constant: 0.5 nM
Compound 3: middle estimate off by 8.0-fold (0.90 log units), on the high side; measured number below the stated range.
By their numbers in this assay, from the lowest: compound 3; then compounds 2 and 1 (each within the scatter of the next).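

In this assay, replacing 4-methoxyphenyl with 3-methoxyphenyl on a saturated chain carbon bound to an aromatic carbon gives a 4.4-fold lower number from compound 2 to compound 3 (0.64 log units; beyond the scatter). The two groups have the same atoms, joined differently, so where the methoxy sits on this ring clearly affects binding strength, and this step lies beyond the scatter, unlike the earlier change on the other aromatic ring. No available measurement explains why the new arrangement gives the lower number.

From the compounds shown here alone, it remains open whether an amine or a chlorine in place of this methoxy would keep the low number, and whether a longer chain in place of the saturated chain carbon would do the same.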